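Para-Halogen Swap on a Tetrabromobenzotriazole Alcohol

This account rests on a few compounds, and the source may have more. Where it says the series, first, only, none or still open, it means among the compounds named here.

Measured compounds:
- Compound 1, `OC(CCn1nc2c(Br)c(Br)c(Br)c(Br)c2n1)c1ccc(F)cc1`: 0%
- Compound 2, `OC(CCn1nc2c(Br)c(Br)c(Br)c(Br)c2n1)c1ccccc1`: 13%
- Compound 3, `OC(CCn1nc2c(Br)c(Br)c(Br)c(Br)c2n1)c1ccc(Br)cc1`: 0%

All three share one core and differ only in the group on the aromatic ring at the far end. In a functional assay on MCF7 cells (Homo sapiens) for antiproliferative activity, read by MTT assay, with a stated time of 24 h, tested at 100 uM (a lower number here means a stronger effect, a higher number a weaker effect of the compound at the concentration tested), compound 1 gives 0%. It stands level with compound 3, which gives 0%; the two are together the lowest of the three numbers, so at this concentration they show the strongest effect. Compound 2, with hydrogen in that position, gives 13%.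

Compound 4, `OC(CCn1nc2c(Br)c(Br)c(Br)c(Br)c2n1)c1ccc(Cl)cc1`, has not yet been measured. Its change from compound 1 is chloro in place of fluoro on an aromatic carbon.

Among the measured compounds shown here, two measured steps bear on this. Replacing fluoro by bromo gave no change at the digits printed from compound 1 to compound 3 (within the scatter). Replacing fluoro by hydrogen gave a number 13 percentage points higher from compound 1 to compound 2 (beyond the scatter). Chloro is a halogen like fluoro and bromo rather than a hydrogen, and both halogen-bearing compounds sit at the same low value, so no step beyond the scatter is expected. Compound 4 is therefore expected to give about 2%, in the range 0% to 12%, which means an expected step of a number 2 percentage points higher from compound 1 to compound 4 (within the scatter).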

Compound 4, a percentage reported as activity, at one concentration (the size of the read-out at that concentration, not a potency): 0%
Estimate against measurement, compound 4: 2 percentage points above; the measured number falls inside the stated range.
By their numbers in this assay, from the lowest: compounds 1, 3 and 4 (each within the scatter of the next); then compound 2.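

In this assay, chloro behaves like the other two halogens on this ring: no change at the digits printed from compound 1 to compound 4 (within the scatter), and no change at the digits printed from compound 3 to compound 4 (within the scatter), so fluoro, chloro and bromo cannot be told apart at this position. The contrast with hydrogen now holds for a third halogen, with a number 13 percentage points lower from compound 2 to compound 4 (beyond the scatter), which makes it a shared feature of all the halogen compounds shown rather than something seen only with fluoro and bromo. Nothing available here explains why the halogens and hydrogen differ.

On these data alone, it remains open whether a group of another kind on this carbon, such as methoxy, an amine or a carboxylic acid, would give the same number as the halogens. As far as these compounds go, all the values also come from a single concentration, so whether compound 1, compound 3 and compound 4 would differ in the size of their effect at any other concentration stays open.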